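Ester chain lengthened once more: compound 3 to compound 4

The compounds below may be only part of what the source reports. "The series", "measured", "known", "first", "only" and "open" are said of these compounds alone.

Measured compounds:
compound 1 `CCCCCCCCOC(=O)CCC(=O)N1CCN(CCCOc2cc3c(Nc4ccc(F)c(Cl)c4)ncnc3cc2OC)CC1` — 87.3% in a functional assay on A549 cells (Homo sapiens) for cytotoxicity, read by MTT assay, with a stated time of 24 h, tested at 10 uM; a higher number here means a weaker effect of the compound at the concentration tested, a lower number a stronger effect
compound 2 `CCCCCCCCCCCOC(=O)CCC(=O)N1CCN(CCCOc2cc3c(Nc4ccc(F)c(Cl)c4)ncnc3cc2OC)CC1` — 93.4%
compound 3 `CCCCCCCCCCCCCOC(=O)CCC(=O)N1CCN(CCCOc2cc3c(Nc4ccc(F)c(Cl)c4)ncnc3cc2OC)CC1` — 93.7%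

Compound 3 has the highest of the three numbers in this assay, but its gaps to compound 2 and to compound 1 both lie within the scatter, so no ordering can be read from them. Compound 4 `CCCCCCCCCCCCCCCCCCOC(=O)CCC(=O)N1CCN(CCCOc2cc3c(Nc4ccc(F)c(Cl)c4)ncnc3cc2OC)CC1` carries the change (pentyl in place of hydrogen on a saturated chain carbon, ten or more bonds along the chain from an oxygen next to a carbonyl group).

Three earlier steps bear on it, all extending the same chain: a number 6.1 percentage points higher from compound 1 to compound 2 (within the scatter), a number 6.4 percentage points higher from compound 1 to compound 3 (within the scatter) and a number 0.3 percentage points higher from compound 2 to compound 3 (within the scatter). None moved the number beyond the scatter. Compound 4 is therefore expected to stay close to compound 3, with an estimated step of a number 0.3 percentage points higher from compound 3 to compound 4 (within the scatter). The estimate for compound 4 in this assay is 94%, with a range from 85% to 101%.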

Compound 4, a percentage reported as activity, at one concentration (the size of the read-out at that concentration, not a potency): 94.8%
Compound 4: middle estimate off by 0.8 percentage points, on the low side; the range from low to high includes it.
By their numbers in this assay, from the lowest: compounds 1, 2, 3 and 4 (each within the scatter of the next).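

In this assay, the added pentyl gives a number 1.1 percentage points higher from compound 3 to compound 4 (within the scatter), while the longer additions give a number 1.4 percentage points higher from compound 2 to compound 4 (within the scatter) and a number 7.5 percentage points higher from compound 1 to compound 4 (within the scatter). Even the decyl difference, at eight bonds along the chain from an oxygen next to a carbonyl group, therefore stays within the scatter, so lengthening this chain produces no readable change across these four compounds at the concentration tested. No evidence bearing on this result is available.

On these data alone, whether a carboxylic acid or an amine in place of this chain would move the number beyond the scatter remains open, as does the effect of a shorter chain.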